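The source may hold more compounds than are shown below. What is called first, only, known or untested is meant among the compounds shown, and "the series" means these compounds.

Measured compounds in an assay on isolated protein for positive allosteric modulation of muscarinic acetylcholine receptor M5 (Homo sapiens); a lower number here means that less compound is needed, a higher number that more compound is needed for the effect:
- compound 1, `O=C1C(=O)N(CCOc2ccc(Oc3ccccc3)cc2)c2ccc(OC(F)(F)F)cc21`: 1050 nM; 1050 nM (2 entries)
- compound 3, `COc1ccc(OCCN2C(=O)C(=O)c3cc(OC(F)(F)F)ccc32)cc1`: 589 nM; 590 nM (2 entries)
- compound 2, `COc1ccc(CN2C(=O)C(O)(c3ccc(F)nc3)c3cc(OC(F)(F)F)ccc32)cc1`: 2200 nM

Compound 1 and compound 3 share a core carrying a trifluoromethoxy group and an ether-linked side chain on the ring nitrogen, and each has been measured more than once with closely agreeing results, as shown for compound 3 by the several entries of compound 3 in this assay, 589 nM; 590 nM (2 entries). Compound 2 differs in that the ring nitrogen bears a 4-methoxybenzyl group and one carbonyl of the core has become a carbon bearing a hydroxyl and a 6-fluoropyridin-3-yl group. In this assay, for the measured compounds named here, compound 2 gives 2200 nM, the only number it has produced; two further attempts ended without a single number.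

Compound 4, `COc1ccc(CN2C(=O)C(O)(C[N+](=O)[O-])c3cc(OC(F)(F)F)ccc32)cc1`, keeps everything of compound 2 except one change: nitromethyl in place of 6-fluoropyridin-3-yl on a saturated ring carbon. Going by the values given here, no pair of measured compounds differs in this same way, so there is no measured step to lean on. A small aliphatic nitromethyl group standing in for an aromatic ring is a sizeable alteration at a position where compound 2 is already modest, and the direction of the change is uncertain.

Compound 4 is expected to come out around 5000 nM, within 1500 nM to 20000 nM, which means an expected step of a 2.3-fold higher number from compound 2 to compound 4 (0.36 log units; beyond the scatter).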

Compound 4, half-maximal effective concentration: 1400 nM
Beside the measured number, compound 4's estimate is 3.6-fold (0.55 log units) above it, outside the stated range (below it).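

In this assay putting nitromethyl in place of 6-fluoropyridin-3-yl on the saturated ring carbon gives a 1.6-fold lower number from compound 2 to compound 4 (0.20 log units; within the scatter) and so leaves the reading of this position unmoved. Until now compound 2 had no partner differing in one place, so nothing showed whether the aromatic ring at this carbon mattered for the number; here a group with no ring and 4 heavy atoms reads the same, within the scatter, as one with a six-membered aromatic ring and 7 heavy atoms, so in this pair the ring is not needed to keep the number at this level. Nothing measured here explains why these two different groups read alike.

A single pair cannot tell whether other groups on this carbon, such as an amine, a carboxylic acid or a longer chain, would also leave the number where it is. Also open is whether the 4-methoxybenzyl group on the ring nitrogen has any part in this result, since no compound shown changes that group alone.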